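Aryl swap on the ring amine: a low-activity pair

This account rests on a few compounds, and the source may have more. Where it says the series, first, only, none or still open, it means among the compounds named here.

Compound 1 `Nc1scc(CN2CCN(c3ccc(OC(F)(F)F)cc3)CC2)c1C(=O)c1ccc(Cl)cc1` is one of two measured members of the series. In a functional assay on CHO cells with adenosine receptor A1 (Homo sapiens) as the target, read by cAMP accumulation and immunoassay, with a stated time of 6 min, tested at 0.01 uM (on this read-out lower numbers stand for a stronger effect and higher numbers for a weaker effect at the one concentration tested), compound 1 gives 0%. Compound 2 `Nc1scc(CN2CCC(c3ccc(Cl)cc3)CC2)c1C(=O)c1ccc(Cl)cc1` is its nearest measured neighbour; in this assay compound 2 gives 0%. On the digits shown, compound 1 stands level with compound 2, the two values falling within the scatter of each other, so no order between them can be read. Going by the values given here, no step between measured compounds that differ in one place is available.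

Compound 3 `Nc1scc(CN2CCN(c3c(F)cc(F)cc3F)CC2)c1C(=O)c1ccc(Cl)cc1` is not yet measured in this assay. It differs from compound 1 by 2,4,6-trifluorophenyl in place of 4-(trifluoromethoxy)phenyl on an amine nitrogen in a ring: the group that leaves has one hydrogen-bond acceptor, the group that enters has none, and the place is an amine nitrogen in a ring of a six-membered non-aromatic ring with 2 nitrogen.

With no shown step to lean on, the expectation for compound 3 in this assay is a step of no change at the digits printed from compound 1 to compound 3 (within the scatter), that is, no change beyond the scatter. Compound 3 is estimated at 0%, within -10% to 12%.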

Compound 3, a percentage reported as activity, at one concentration (the size of the read-out at that concentration, not a potency): 4.2%
For compound 3 the middle estimate is 4.2 percentage points below the measured one; measured number inside the range.
By their numbers in this assay, from the lowest: compounds 1, 2 and 3 (each within the scatter of the next).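

Going by these compounds alone, replacing 4-(trifluoromethoxy)phenyl with 2,4,6-trifluorophenyl on the amine nitrogen in the six-membered non-aromatic ring gives a number 4.2 percentage points higher from compound 1 to compound 3 (within the scatter) in this assay at the one concentration tested, and this is the first one-place step available. Within the data shown here, at this position, the read-out does not separate the two aryl groups, even though the hydrogen-bond acceptor counted on the leaving group has no counterpart on the entering group and the entering group is the smaller by heavy atoms. No supporting measurement bears on this result, and the step offers no basis for an explanation.

A single step between two fluorine-bearing phenyl groups, read at one concentration, leaves open whether these aryl groups would separate at other concentrations, where a full concentration-response reading could show differences that this read-out does not. Also open, from the compounds shown here alone, is what a benzyl group, a pyridyl ring or a phenyl ring bearing a carboxylic acid would give on the same amine nitrogen.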